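A few compounds are considered here, and "the series" means these few. Any claim that something is new, unique, unknown or untested is made for them only; others in the source may bear on it.

Measured in an ADME assay on HFF cells (Homo sapiens) for cytotoxicity, read by MTT assay, with a stated time of 72 h; a lower number here means a stronger inhibitor, a higher number a weaker inhibitor:
compound 1 `O=C1O/C(=C\Cn2cc(-c3cc(F)cc(F)c3)nn2)C(OCc2ccccc2)=C1OCc1ccccc1`, > 100000 nM
compound 2 `O=C1O[C@H]([C@@H](O)Cn2cc(-c3cccc(O)c3)nn2)C(OCc2ccccc2)=C1OCc1ccccc1`, 39000 nM
compound 3 `O=C1O[C@H]([C@@H](O)Cn2cc(CNS(=O)(=O)c3ccc(Cl)cc3F)nn2)C(OCc2ccccc2)=C1OCc1ccccc1`, 20 nM

The value given for compound 1 is a limit of this assay, not a number. Of the two numbers, compound 2 stands highest; its nearest neighbour is compound 3, whose number lies far lower, well beyond the scatter. Compound 4 `COc1ccc(-c2cn(C[C@H](O)[C@H]3OC(=O)C(OCc4ccccc4)=C3OCc3ccccc3)nn2)cc1` differs from compound 2 in one place: 4-methoxyphenyl in place of 3-hydroxyphenyl on an aromatic carbon. Among the measured compounds shown here, no measured pair differs in that way, so the size of such a step has not been seen in this assay. The expected step from compound 2 to compound 4 is a 1.0-fold higher number from compound 2 to compound 4 (0.01 log units; within the scatter), no change beyond the scatter in either direction. Compound 4 is therefore estimated at 40000 nM, within a range of 10000 nM to 150000 nM.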

Compound 4, half-maximal inhibitory concentration: < 10 nM
Compound 4 was reported as a limit; the forecaster's own chance of this, stated with the estimate: 30%; middle value at least 4000-fold (3.60 log units) from the limit.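

In this assay, putting 4-methoxyphenyl in place of 3-hydroxyphenyl on this aromatic carbon gives an at least 3900-fold lower number from compound 2 to compound 4 (3.59 log units; beyond the scatter), which shows that a single change of the phenyl substituent at this position can move the read-out across nearly the whole span of values shown. Compound 4 gives < 10 nM, which is a limit of the assay and not a number. The step is therefore a bound and not a measured size: the limit of < 10 nM in this assay, at which 1 of the 4 values shown sits.

The compounds shown leave open whether 3-methoxyphenyl or 4-hydroxyphenyl would read like compound 2 or like compound 4, so the substituent and its ring position cannot yet be separated. From the compounds shown here alone, how an amine on the same phenyl ring would read also remains open.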